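Fluorine shift on the benzyl group of compound 2

The source may report more compounds than this note shows. Statements on the series, on what has been measured and on what is new or still open speak of the compounds shown alone.

Measured in a physicochemical assay for lipophilicity, at pH 7.4; on this read-out lower numbers stand for lower lipophilicity and higher numbers for higher lipophilicity:
- compound 1 `Cc1cc(N[C@H](CCCCN)C(=O)NO)cc(C)c1F`: < 3
- compound 2 `Cc1cc(N[C@H](CCCCNCc2ccccc2F)C(=O)NO)cc(C)c1F`: < 3

Compound 1 gives < 3, which is a limit of the assay and not a number. Compound 2 gives < 3, again only a limit, so its position in the series cannot be given as a number. The two readings stand together: the limit of < 3 in this assay, at which 2 of the 2 values shown sit. Among the measured compounds shown here, the only measured step is a step that the two limits leave unreadable from compound 1 to compound 2, with 2-fluorobenzyl in place of hydrogen on an amine nitrogen. It offers no size to carry forward.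

Compound 3 `Cc1cc(N[C@H](CCCCNCc2cccc(F)c2)C(=O)NO)cc(C)c1F` differs from compound 2 by 3-fluorophenyl in place of 2-fluorophenyl on a saturated chain carbon bound to an amine nitrogen. The two have the same atoms, joined differently. For the measured compounds named here, no measured step makes this exchange, so no direction can be argued, and no step beyond the scatter is expected in this assay. The expected step is a step that the limit leaves unreadable from compound 2 to compound 3, and another limit is the likely report. For compound 3 the estimated value is 2.5, with an expected range from 1.8 to 3.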

Compound 3, distribution coefficient: < 3
Compound 3 was reported as a limit (the forecaster's own chance of this, stated with the estimate: 85%); the middle value does not contradict the limit.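

Compound 1, compound 2 and compound 3 are all reported as limits in this assay, not as numbers, so no new step can be read among them: the limit of < 3 in this assay, at which 3 of the 3 values shown sit.

Still open, as far as these compounds go, is where each compound falls as a number in this assay, and whether 2-fluorobenzyl, 3-fluorobenzyl and hydrogen on the amine nitrogen separate at all.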